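The compounds below may be only part of what the source reports. "The series", "measured", "known", "first", "only" and "open" are said of these compounds alone.

For the measured compounds named here, in a physicochemical assay for solubility, read by HPLC, in phosphate buffer, measured as kinetic solubility, with a stated time of 1 h, at pH 7.4, tested at 250 uM (on this read-out lower numbers stand for lower solubility and higher numbers for higher solubility), compound 1 `CC(C)CNC(=O)n1c(=O)oc2cc(C3CCN(C)CC3)ccc21` gives 240000 nM and compound 2 `CCCCCNC(=O)n1c(=O)oc2cc(C3CCN(C)CC3)ccc21` gives 240000 nM as well, so compound 2 stands level with its only measured neighbour. Next comes compound 3 `CN1CCC(c2ccc3c(c2)oc(=O)n3C(=O)NCCOCc2ccccc2)CC1`, with benzyloxy in place of propyl on a saturated chain carbon, two bonds along the chain from an amide-type nitrogen. Going by the values given here, only one measured step bears on this change, no change at the digits printed from compound 1 to compound 2 (within the scatter) between two chains without a ring, and it is a weak guide, since no measured compound carries a ring in that chain. In this assay a small fall is expected, quite possibly none beyond the scatter, and both measured values lie close to the tested concentration, which leaves little room upward. The expected step is a 1.4-fold lower number from compound 2 to compound 3 (0.15 log units; within the scatter) on this estimate. For compound 3 the estimated value is 170000 nM within an expected range of 60000 nM to 250000 nM for now.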

Compound 3, solubility: 73000 nM
Beside the measured number, compound 3's estimate is 2.3-fold (0.37 log units) above it; the range from low to high includes it.
By their numbers in this assay, from the lowest: compound 3; then compounds 1 and 2 (each within the scatter of the next).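

In this assay, this position on the chain now proves able to move the number: the two chains without a ring gave no change at the digits printed from compound 1 to compound 2 (within the scatter), whereas benzyloxy in place of propyl on a saturated chain carbon, two bonds along the chain from an amide-type nitrogen, gives a 3.3-fold lower number from compound 2 to compound 3 (0.52 log units; beyond the scatter). Read against the other chain without a ring, (benzyloxy)methyl in place of isopropyl gives the same size of step, a 3.3-fold lower number from compound 1 to compound 3 (0.52 log units; beyond the scatter), so the fall does not rest on one reference compound alone. No measurement at hand accounts for this fall.

Benzyloxy brings in its aromatic ring and its oxygen together, and the compounds shown do not separate the two. Also open, on these data alone, is how a chain ending in a carboxylic acid or a dimethylamine would read in this assay.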